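Swapping a Ring Ether for a Branched Chain Ether

This account rests on a few compounds, and the source may have more. Where it says the series, first, only, none or still open, it means among the compounds named here.

Three compounds have been measured in an assay on SK-BR-3 cells for inhibition of Aromatase (Homo sapiens); on this read-out lower numbers stand for stronger inhibition and higher numbers for weaker inhibition:
- compound 1 `CCC(CC)Oc1cc([N+](=O)[O-])ccc1NS(C)(=O)=O` gives 300 nM
- compound 2 `CCCOc1cc([N+](=O)[O-])ccc1N(C)S(C)(=O)=O` gives 760 nM
- compound 3 `CN(c1ccc([N+](=O)[O-])cc1OCC1CCCCC1)S(C)(=O)=O` gives 960 nM

Compound 3 shows the highest number of the three; compound 2 sits within the scatter of it, while compound 1 lies beyond the scatter with a lower number. Compound 4 `CCC(CC)Oc1cc([N+](=O)[O-])ccc1N(C)S(C)(=O)=O` carries pentan-3-yl in place of cyclohexylmethyl on an oxygen on an aromatic ring. For the measured compounds named here, only one measured step changes this ether group, a 1.3-fold higher number from compound 2 to compound 3 (0.10 log units; within the scatter), and it stayed within the scatter. Compound 1 bears the same pentan-3-yl ether as compound 4 but differs from it in another place, so its value offers only a hint of a lower number. The expected step of a 1.6-fold lower number from compound 3 to compound 4 (0.20 log units; within the scatter) is therefore modest, toward a lower number. Compound 4 is estimated at 600 nM, with a range from 250 nM to 1500 nM.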

Compound 4, half-maximal inhibitory concentration: 230 nM
The estimate for compound 4 lay 2.6-fold (0.42 log units) above the measured number; measured number outside the range, below it.
By their numbers in this assay, from the lowest: compounds 4 and 1 (each within the scatter of the next); then compounds 2 and 3 (each within the scatter of the next).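

The ether group on this oxygen matters in this assay: pentan-3-yl in place of cyclohexylmethyl gives a step beyond the scatter (a 4.2-fold lower number from compound 3 to compound 4 (0.62 log units; beyond the scatter)), the first such step seen at this place. Ethyl in place of hydrogen on the chain carbon bound to the oxygen also counts (a 3.3-fold lower number from compound 2 to compound 4 (0.52 log units; beyond the scatter)), whereas methyl in place of hydrogen on the sulfonamide nitrogen stays within the scatter (a 1.3-fold lower number from compound 1 to compound 4 (0.12 log units; within the scatter)). No measurement here explains these differences.

On these data alone, whether a smaller branched ether such as isopropyl, or a cyclopentyl ether, would match compound 4 remains open.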